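Bromo for isopropyl on the aryl ring of compound 3

The compounds below may be only part of what the source reports. "The series", "measured", "known", "first", "only" and "open" are said of these compounds alone.

Compound 3 `CC(C)c1ccc(Nc2nc(SCc3cn(CC(=O)NC(=O)Nc4ccccn4)nn3)nc(-c3ccc(C(C)C)cc3)c2C#N)cc1` gives 15800 nM in a functional assay on MGC-803 cells (Homo sapiens) for inhibition, read by MTT assay, with a stated time of 72 h; on this read-out lower numbers stand for stronger inhibition and higher numbers for weaker inhibition. Among the two numbers shown it is the lowest, though compound 2 `Cc1cccc(Nc2nc(SCc3cn(CC(=O)NC(=O)Nc4ccccn4)nn3)nc(-c3ccc(C(C)C)cc3)c2C#N)c1`, at 25300 nM, sits a 1.6-fold lower number from compound 2 to compound 3 (0.20 log units; within the scatter). Compound 1 `CC(C)c1ccc(-c2nc(SCc3cn(CC(=O)NC(=O)Nc4ccccn4)nn3)nc(Nc3ccc(Cl)cc3)c2C#N)cc1` gives only a limit, > 64000 nM (the limit of > 64000 nM in this assay, at which 1 of the 3 values shown sits). Compound 4 `CC(C)c1ccc(Nc2nc(SCc3cn(CC(=O)NC(=O)Nc4ccccn4)nn3)nc(-c3ccc(Br)cc3)c2C#N)cc1` differs from compound 3 by bromo in place of isopropyl on an aromatic carbon. The measured step most like it runs the opposite way on the other ring: an at least 4.0-fold lower number from compound 1 to compound 3 (0.60 log units; beyond the scatter), isopropyl in place of chloro. Taking a halogen for isopropyl as the reverse of that, a modestly higher number is expected for compound 4 in this assay, a 2.5-fold higher number from compound 3 to compound 4 (0.40 log units; beyond the scatter). Compound 4 is therefore estimated at 40000 nM, between 15000 nM and 110000 nM.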

Compound 4, half-maximal inhibitory concentration: 15600 nM
Estimate against measurement, compound 4: 2.6-fold (0.41 log units) above, within the range that was stated.
By their numbers in this assay, from the lowest: compounds 4, 3 and 2 (each within the scatter of the next). At a limit, above all of these: compound 1.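

Bromo in place of isopropyl on this aryl ring gives a 1.0-fold lower number from compound 3 to compound 4 (0.01 log units; within the scatter) in this assay, so at this place one bromine stands in for the three carbons of isopropyl with no readable change. This is the first step shown on this ring, and it does not mirror the step on the ring carried by the nitrogen, which rests on a limit for compound 1: the limit of > 64000 nM in this assay, at which 1 of the 4 values shown sits.

The compounds shown leave open how an amine or a carboxylic acid would read at this place. They also leave open whether a longer chain would hold the value.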